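Smaller Group on the Sulfonamide Nitrogen in Compound 3

The compounds below may be only part of what the source reports. "The series", "measured", "known", "first", "only" and "open" are said of these compounds alone.

Compound 1 `CCC(=O)N1CCC(CN(C2Cc3cc(C#N)ccc3N(Cc3cncn3C)C2)S(=O)(=O)c2ccccn2)CC1` gives 0.5 10^-6 cm/s in an ADME assay on Caco-2 cells (Homo sapiens) for permeability, in the apical to basolateral direction (on this read-out lower numbers stand for lower permeability and higher numbers for higher permeability), the higher of the two measured numbers. Within the data shown here, compound 2 `Cn1cnc(S(=O)(=O)N2CCC(CN(C3Cc4cc(C#N)ccc4N(Cc4cncn4C)C3)S(=O)(=O)c3ccccn3)CC2)c1` gives 0.1 10^-6 cm/s, and the single measured step, a 5.0-fold lower number from compound 1 to compound 2 (0.70 log units; beyond the scatter), concerns a change at a different place in the molecule. Compound 3 `Cc1noc(C)c1CN(C1Cc2cc(C#N)ccc2N(Cc2cncn2C)C1)S(=O)(=O)c1ccccn1` differs from compound 1 by 3,5-dimethyl-1,2-oxazol-4-yl in place of 1-propanoylpiperidin-4-yl on a saturated chain carbon bound to a sulfonamide nitrogen. Among the measured compounds shown here, no measured step covers a change at this place, so the known step offers only a loose guide. A modest rise is expected, a 4.0-fold higher number from compound 1 to compound 3 (0.60 log units; beyond the scatter). Compound 3 is estimated at 2 10^-6 cm/s, with a range from 0.5 10^-6 cm/s to 6 10^-6 cm/s.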

Compound 3, apparent permeability: 8 10^-6 cm/s
Compound 3: the middle estimate sits 4.0-fold (0.60 log units) below what was measured; measured number outside the range, above it.
By their numbers in this assay, from the lowest: compound 2; then compound 1; then compound 3.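

Swapping 1-propanoylpiperidin-4-yl for 3,5-dimethyl-1,2-oxazol-4-yl on a saturated chain carbon bound to a sulfonamide nitrogen gives a 16-fold higher number from compound 1 to compound 3 (1.20 log units; beyond the scatter) in this assay, so this place, untouched in the earlier pair, can raise the number strongly. The change replaces a six-membered non-aromatic ring with a five-membered aromatic one and also removes the propanoyl group, so several features change at once. No evidence here bears on why the number rises. On these data alone, it remains open which feature matters; a phenyl ring or an unsubstituted piperidin-4-yl at this place would help separate them.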